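The source may hold more compounds than are shown below. What is called first, only, known or untested is meant among the compounds shown, and "the series" means these compounds.

Of the compounds shown here, two from this study have been tested in a functional assay on MGC-803 cells (Homo sapiens) for antiproliferative activity, read by CCK-8 assay, with a stated time of 72 h, tested at 8 uM; a higher number here means a stronger effect of the compound at the concentration tested, a lower number a weaker effect. Compound 1, `Nc1ccccc1NC(=O)c1ccc(CSC(=S)N2CCN(c3ccc(Cl)cc3)CC2)cc1`, gives 17.2% in this assay. Compound 2, `CCN(Cc1ccncc1)C(=S)SCc1ccc(C(=O)Nc2ccccc2N)cc1`, gives 85.2% in this assay. Compound 1 therefore holds the lower of the two numbers, and the gap to compound 2 lies beyond the usual scatter. Among the measured compounds shown here, no step between these two compounds has been worked out; only their two values stand side by side.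

Compound 3, `Nc1ccccc1NC(=O)c1ccc(CSC(=S)N2CCN(c3ccccc3)CC2)cc1`, has not yet been measured in this assay. It differs from compound 1 in one place: hydrogen in place of chloro on an aromatic carbon. For the measured compounds named here, no measured pair shows what such a change does here. Since only a single chlorine leaves and a hydrogen takes its place, the step of a number 2.8 percentage points higher from compound 1 to compound 3 (within the scatter) is expected to be small, within the scatter, in either direction. Compound 3 is expected to give 20% in this assay, with a range from 5% to 40%.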

Compound 3, a percentage reported as inhibition, at one concentration (the size of the read-out at that concentration, not a potency): 87.4%
Compound 3: middle estimate off by 67.4 percentage points, on the low side, and the stated range ends below it.
By their numbers in this assay, from the lowest: compound 1; then compounds 2 and 3 (each within the scatter of the next).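

In this assay, going from 4-chlorophenyl to phenyl gives a number 70.2 percentage points higher from compound 1 to compound 3 (beyond the scatter), so this place on the aromatic ring, para to a large group, strongly affects the read-out at the concentration tested. With this single pair, the low value of compound 1 can now be tied to one atom, the chlorine, rather than to the structure as a whole. Nothing available explains why removing the chlorine has so large an effect.

As far as these compounds go, it remains open whether a fluoro, methyl or methoxy group at this place would read like the chloro of compound 1 or like the hydrogen of compound 3. From the compounds shown here alone, because the read-out comes from one concentration, the size of any difference in potency between compound 1 and compound 3 also remains open.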